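The source may report more compounds than this note shows. Statements on the series, on what has been measured and on what is new or still open speak of the compounds shown alone.

Of the compounds shown here, three with a shared core have been tested in a functional assay on Jurkat cells (Homo sapiens) for inhibition, read by CCK-8 assay, with a stated time of 48 h; on this read-out higher numbers stand for weaker inhibition of growth and lower numbers for stronger inhibition of growth. Compound 1 `Cc1ccccc1Nc1nc(NC2CC2)ncc1Cl` gives > 100000 nM, which is a limit and not a number. Compound 2 `Cc1ccccc1Nc1nc(Nc2ccc(N3CCCCC3)cn2)ncc1Cl` gives > 100000 nM, again a limit. Compound 3 `CN1CCN(c2ccc(Nc3ncc(Cl)c(Nc4ccccc4)n3)nc2)CC1` gives > 100000 nM, also a limit, and so it stands with the others at the limit of > 100000 nM in this assay, at which 3 of the 3 values shown sit.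

Compound 4 `COc1ccc(CNc2nc(Nc3ccc(N4CCN(C)CC4)cn3)ncc2Cl)cc1` carries 4-methoxybenzyl in place of phenyl on a nitrogen on an aromatic ring. For the measured compounds named here, no measured step shows what such a change does in this assay, so only a small shift toward stronger inhibition of growth is expected, and the result may well stay at the limit. The expected step is an at least 1.6-fold lower number from compound 3 to compound 4 (0.22 log units; that floor lies within the scatter). For compound 4 the estimate is 60000 nM, with an expected range from 8000 nM to 100000 nM.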

Compound 4, concentration for 50% growth inhibition: 12900 nM
For compound 4 the middle estimate is 4.7-fold (0.67 log units) above the measured one, and the stated range covers the measured number.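

Putting 4-methoxybenzyl in place of phenyl on a nitrogen on an aromatic ring gives the only compound shown in this assay with a number rather than a limit, and the step is an at least 7.7-fold lower number from compound 3 to compound 4 (0.88 log units; beyond the scatter). This shows that the position can move the read-out toward stronger inhibition of growth. The earlier compounds offered no such contrast: the limit of > 100000 nM in this assay, at which 3 of the 4 values shown sit.

Still open, going by these compounds, is which part of the new group matters, the methoxy group or the longer link to the ring. Plain benzyl or a 2-phenylethyl group at this nitrogen would help separate the two.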